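The compounds below may be only part of what the source reports. "The series", "measured", "known", "first", "only" and "open" are said of these compounds alone.

Measured in an ADME assay on MT4 cells (Homo sapiens) for cytotoxicity, read by MTT assay; a lower number here means that less compound is tolerated, a higher number that more compound is tolerated:
- compound 1 `Cc1ccccc1C(=O)N(C(=S)OCCN1C(=O)c2ccccc2C1=O)c1ccc(Cl)cc1` gives 21000 nM
- compound 2 `Cc1ccc(C(=O)N(C(=S)OCCN2C(=O)c3ccccc3C2=O)c2ccc(Cl)cc2)cc1` gives > 100000 nM, a limit of the assay and not a number
- compound 3 `O=C1c2ccccc2C(=O)N1CCOC(=S)N(C(=O)c1c(Cl)cccc1Cl)c1ccc(Cl)cc1` gives 20000 nM

Compound 3 stands level with compound 1, and the exchange between them is a 1.1-fold lower number from compound 1 to compound 3 (0.02 log units; within the scatter). Going by the values given here, compound 2 is the only member that sits at the limit of > 100000 nM in this assay, at which 1 of the 3 values shown sits.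

The next step leads to compound 4 `COc1cccc(OC)c1C(=O)N(C(=S)OCCN1C(=O)c2ccccc2C1=O)c1ccc(Cl)cc1`. The change is 2,6-dimethoxyphenyl in place of 2,6-dichlorophenyl on a carbonyl carbon, which is 2,6-dimethoxyphenyl in place of 2,6-dichlorophenyl on a carbonyl carbon. Among the compounds with values here, all measured steps exchange a group at this same place, but no measured compound carries 2,6-dimethoxyphenyl.

The step with numbers at both ends is a 1.1-fold lower number from compound 1 to compound 3 (0.02 log units; within the scatter), so it offers the best guide. The two larger steps are an at least 4.7-fold higher number from compound 1 to compound 2 (0.67 log units; beyond the scatter) and an at least 5.0-fold lower number from compound 2 to compound 3 (0.69 log units; beyond the scatter). Each of these is only a bound, and both turn on the 4-methylphenyl group, which compound 4 does not carry. They still show that this place can move the read-out, so a wide range is kept on the upper side.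

The expected change is a 1.3-fold higher number from compound 3 to compound 4 (0.10 log units; within the scatter), which means no step beyond the scatter is expected in this assay. For compound 4 the estimated value is 25000 nM, with an expected range of 9000 nM to 90000 nM.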

Compound 4, half-maximal cytotoxic concentration: 69000 nM
Compound 4: the middle estimate sits 2.8-fold (0.44 log units) below what was measured, within the range that was stated.
By their numbers in this assay, from the lowest: compounds 3 and 1 (each within the scatter of the next); then compound 4. At a limit, above all of these: compound 2.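

In this assay the exchange of 2,6-dichlorophenyl for 2,6-dimethoxyphenyl gives a 3.5-fold higher number from compound 3 to compound 4 (0.54 log units; beyond the scatter), and the exchange of 2-methylphenyl for the same group gives a 3.3-fold higher number from compound 1 to compound 4 (0.52 log units; beyond the scatter). Going by these compounds alone, these are the first steps at this place with numbers at both ends that lie beyond the scatter, the earlier such step having stayed within it, and they show that 2,6-dichlorophenyl and 2,6-dimethoxyphenyl give different numbers. Against the 4-methylphenyl group only a floor can be read, an at least 1.4-fold lower number from compound 2 to compound 4 (0.16 log units; that floor lies within the scatter), and the true size of that gap remains unknown.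

Compound 2 gives a limit and not a number, which leaves its distance from every other member open: the limit of > 100000 nM in this assay, at which 1 of the 4 values shown sits. Also open, from the compounds shown here alone, are how an amine or a carboxylic acid on the aromatic ring at this place would read, and whether the step seen with 2,6-dimethoxyphenyl would hold if another part of the shared core were changed.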